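This account rests on a few compounds, and the source may have more. Where it says the series, first, only, none or still open, it means among the compounds named here.

Compound 2, `N#CC1=C(NC(=O)c2ccccc2)N(c2ccc(S(N)(=O)=O)cc2)C2=C(C(=O)CCC2)C1c1ccc(Cl)cc1Cl`, gives 75% in a functional assay on Ehrlich cells (Mus musculus) for cytotoxicity, read by trypan blue exclusion, with a stated time of 2 h, tested at 100 ug/mL; a lower number here means a weaker effect, a higher number a stronger effect of the compound at the concentration tested. Going by the values given here, of the two numbers measured so far it stands highest; the nearest is compound 1, `CC(Cl)CC(=O)NC1=C(C#N)C(c2ccc(Cl)cc2Cl)C2=C(CCCC2=O)N1c1ccc(S(N)(=O)=O)cc1`, which in this assay gives 60%, with a step of a number 15 percentage points higher from compound 1 to compound 2 (beyond the scatter). Compound 3, `N#CC1=C(NC(=O)/C=C/c2ccccc2)N(c2ccc(S(N)(=O)=O)cc2)C2=C(C(=O)CCC2)C1c1ccc(Cl)cc1Cl`, has not been measured; it differs from compound 2 by 2-phenylethenyl in place of phenyl on a carbonyl carbon. Among the compounds with values here, only one measured step exists, a number 15 percentage points higher from compound 1 to compound 2 (beyond the scatter), and it concerns a different change on the same carbonyl carbon, from 2-chloropropyl to phenyl, so it bears on the new step only by showing that this carbonyl substituent can move the read-out by a modest amount. Within the data shown here, no measured pair tells whether 2-phenylethenyl in place of phenyl adds or takes away. The estimated step is therefore a number 3 percentage points higher from compound 2 to compound 3 (within the scatter), not clearly beyond the scatter, and compound 3 is expected to give about 78%, in the range 60% to 92%.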

Compound 3, a percentage reported as activity, at one concentration (the size of the read-out at that concentration, not a potency): 45%
Compound 3: middle estimate off by 33 percentage points, on the high side; the measured number lies below the stated range.
By their numbers in this assay, from the lowest: compound 3; then compound 1; then compound 2.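

In this assay, going from phenyl to 2-phenylethenyl on this carbonyl carbon keeps the aromatic ring and adds a double bond outside it, and the change amounts to a number 30 percentage points lower from compound 2 to compound 3 (beyond the scatter). Set against the 2-chloropropyl group, the same 2-phenylethenyl group gives a number 15 percentage points lower from compound 1 to compound 3 (beyond the scatter), so among these three compounds an aromatic ring at this position does not by itself go with the higher number, and the group attached to the amide carbonyl can move the read-out in either direction. Nothing among the data offers an explanation for these differences.

As far as these compounds go, it remains open whether the fall follows the double bond or the longer reach of the group, which a saturated 2-phenylethyl group would help to separate. From the compounds shown here alone, how a simple methyl group or an aminomethyl group would behave on this carbonyl carbon is also open.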